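This account rests on a few compounds, and the source may have more. Where it says the series, first, only, none or still open, it means among the compounds named here.

In an ADME assay on TERT-RPE1 cells (Homo sapiens) for cytotoxicity, read by MTT assay, with a stated time of 72 h (a higher number here means a weaker inhibitor, a lower number a stronger inhibitor), compound 1 `COc1ccc(/C=C2\S/C(=N\c3ccccc3)N(C)C2=O)cc1` gives > 100000 nM, which is a limit of the assay rather than a number; compound 1 thus sits at the limit of > 100000 nM in this assay, at which 1 of the 3 values shown sits. Compound 2 `COc1ccc(/C=C2/CN(C)/C(=N/c3ccc(F)cc3)S2)cc1` gives 42800 nM in this assay, and compound 3 `COc1ccc(/C=C2/CN(C)/C(=N/c3ccc(C(C)(C)C)cc3)S2)cc1` gives 23500 nM. Within the data shown here, the only measured step, a 1.8-fold lower number from compound 2 to compound 3 (0.26 log units; within the scatter), exchanges a group on an aromatic carbon within a different core and stays within the scatter. Compound 4 `C=CC/N=C1\S/C(=C\c2ccc(OC)cc2)C(=O)N1C` differs from compound 1 by allyl in place of phenyl on a double-bonded nitrogen. Among the measured compounds shown here, no measured step alters the same place, so the step of a number no higher from compound 1 to compound 4 (the limit leaves the size open) is expected to keep compound 4 near the limit, with no direction beyond the scatter. Compound 4 is therefore estimated at 100000 nM, with a range from 30000 nM to 300000 nM.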

Compound 4, half-maximal inhibitory concentration: > 100000 nM
Compound 4: a limit, no number; the forecaster's own chance of this, stated with the estimate: 60%; the middle value lies on the limit itself.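

Among these compounds, compound 1 and compound 4 both stand as limits rather than numbers in this assay, and no step between them can be read. The compounds shown leave open whether allyl in place of phenyl on a double-bonded nitrogen changes the number at all.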